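The source may report more compounds than this note shows. Statements on the series, on what has been measured and on what is new or still open speak of the compounds shown alone.

Of the compounds shown here, two have been measured here. Compound 1 `Cn1c(-c2cccc(Cl)c2)nc2c(NC3CCCC3)ncnc21` and compound 2 `CCCn1c(-c2ccccc2)nc2c(NC3CCC3)ncnc21` share the same fused core, and both were tested in an assay on CHO cells for displacement of a labelled ligand from adenosine receptor A3 (Homo sapiens), read by scintillation counting, with a stated time of 3 h; on this read-out lower numbers stand for stronger inhibition and higher numbers for weaker inhibition. Compound 1 gives 514 nM in this assay, and compound 2 gives 264 nM; compound 1 has the higher number of the two, but the gap falls within the scatter of repeated measurements, so the two cannot be told apart.

Compound 3 `Cn1c(-c2ccc(Cl)cc2)nc2c(NC3CCCC3)ncnc21` has not yet been measured. It differs from compound 1 only in one place: 4-chlorophenyl in place of 3-chlorophenyl on an aromatic carbon. Among the compounds with values here, no pair of measured compounds here differs in the same way, so there is no measured step to lean on. Without such a guide, the expected step of a 1.1-fold lower number from compound 1 to compound 3 (0.06 log units; within the scatter) is taken to be small, with no clear direction beyond the scatter. Compound 3 is thus expected to give about 450 nM in this assay, with a likely range from 120 nM to 1700 nM.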

Compound 3, inhibition constant: 1210 nM
Estimate against measurement, compound 3: 2.7-fold (0.43 log units) below, within the range that was stated.
By their numbers in this assay, from the lowest: compounds 2 and 1 (each within the scatter of the next); then compound 3.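

In this assay, putting 4-chlorophenyl in place of 3-chlorophenyl gives a 2.4-fold higher number from compound 1 to compound 3 (0.37 log units; beyond the scatter), and a higher number here means weaker inhibition. Compounds 1 and 2 differ in more than one place, so they could not isolate any single change; this pair shows that, on this aromatic carbon of the shared core, the placement of the chlorine on the phenyl ring alone can shift the reading, even though the two groups contain the same atoms. No measurement shown here accounts for this shift.

As far as these compounds go, it remains open whether a methoxy group or a fluorine in place of the chlorine would read closer to compound 1 or to compound 3. From the compounds shown here alone, it is also open whether this change would give a similar step on compound 2, which carries a propyl chain and a cyclobutyl ring.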